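This account rests on a few compounds, and the source may have more. Where it says the series, first, only, none or still open, it means among the compounds named here.

For the measured compounds named here, compound 3 `CC[N+]1(CCCCCCCOc2ccc(-n3cc(C(=O)Nc4cc(F)cc(F)c4)c(=O)c4ccc(N(C)C)nc43)cc2C)CCCC1` stands at the top of the numbers measured so far in an assay on LX2 cells for inhibition of COL1A1 promoter (Homo sapiens), read by a luciferase reporter, with a stated time of 24 h, tested at 50 uM (a lower number here means a weaker effect, a higher number a stronger effect of the compound at the concentration tested), with a value of 82.5%. Compound 2 `CN1CC[N+](C)(CCCCCCCOc2ccc(-n3cc(C(=O)Nc4cc(F)cc(F)c4)c(=O)c4ccc(N(C)C)nc43)cc2Cl)CC1` gives 15.4% in this assay, a gap to compound 3 well beyond the scatter, while compound 1 `CN(C)c1ccc2c(=O)c(C(=O)Nc3cc(F)cc(F)c3)cn(-c3ccc(OCCCCCCC[N+]4(C)CCCCC4)c(Cl)c3)c2n1` is reported only as "not active" (no number reported), with no number. Compound 4 `CC[N+]1(CCCCCCCOc2ccc(-n3cc(C(=O)Nc4cc(F)cc(F)c4)c(=O)c4ccc(N(C)C)nc43)cc2Cl)CCCC1` carries chloro in place of methyl on an aromatic carbon compared with compound 3. Both compounds that already carry the chloro group, compound 1 and compound 2, sit far below compound 3, although they differ from it in other places too. The step is therefore expected to run downward, and probably beyond the scatter, as a number 27.5 percentage points lower from compound 3 to compound 4 (beyond the scatter). Compound 4 is estimated to reach 55% in this assay, within a range from 20% to 85%.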

Compound 4, a percentage reported as inhibition, at one concentration (the size of the read-out at that concentration, not a potency): 23.5%
Compound 4: middle estimate off by 31.5 percentage points, on the high side; the measured number falls inside the stated range.
By their numbers in this assay, from the lowest: compounds 2 and 4 (each within the scatter of the next); then compound 3.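

In this assay, chloro in place of methyl on the aromatic carbon gives a number 59 percentage points lower from compound 3 to compound 4 (beyond the scatter), so this single position alone accounts for a large change. The ring group at the chain end gives a number 8.1 percentage points higher from compound 2 to compound 4 (within the scatter), so with chloro present the five-membered and six-membered rings do not separate. No measurement shown gives a reason for either step. On these data alone, it remains open whether fluoro, methoxy or plain hydrogen at this position would match methyl, and whether methyl would raise the values of the compounds carrying the six-membered rings.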